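This account rests on a few compounds, and the source may have more. Where it says the series, first, only, none or still open, it means among the compounds named here.

Of the compounds shown here, three that share one core have been measured in a functional assay on HeLa cells (Homo sapiens) for antiproliferative activity, read by MTT assay, with a stated time of 48 h; a lower number here means a stronger inhibitor, a higher number a weaker inhibitor.

Compound 1 `Fc1ccc(CSc2nnc(-c3ccc4c(c3)OCCO4)o2)cc1` gives 41200 nM.
Compound 2 `O=[N+]([O-])c1cccc(CSc2nnc(-c3ccc4c(c3)OCCO4)o2)c1` gives 35600 nM.
Compound 3 `Cc1ccccc1CSc1nnc(-c2ccc3c(c2)OCCO3)o1` gives 19000 nM.

Among these three, compound 3 has the lowest number. Its gap to compound 2 lies within the scatter of repeated measurements, so those two cannot be ranked against each other. Going by the values given here, its gap to compound 1 is the one measured step, a 2.2-fold lower number from compound 1 to compound 3 (0.34 log units; beyond the scatter), a modest change that is beyond the scatter.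

Compound 4 `Clc1ccccc1CSc1nnc(-c2ccc3c(c2)OCCO3)o1` has not yet been measured. It differs from compound 3 in one place: chloro in place of methyl on an aromatic carbon.

Among the compounds with values here, no measured step exchanges chloro for methyl anywhere. Within the data shown here, the only step recorded, a 2.2-fold lower number from compound 1 to compound 3 (0.34 log units; beyond the scatter), replaces 4-fluorophenyl with 2-methylphenyl, a different change, so it offers no guide to the size or direction of this one. With nothing in the measured steps pointing either way, the step expected in this assay is a 1.1-fold lower number from compound 3 to compound 4 (0.02 log units; within the scatter), which is no larger than the scatter and in no firm direction. Compound 4 is therefore estimated at 18000 nM, with a range from 8000 nM to 40000 nM.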

Compound 4, half-maximal inhibitory concentration: 36800 nM
Estimate against measurement, compound 4: 2.0-fold (0.31 log units) below, and the stated range covers the measured number.
By their numbers in this assay, from the lowest: compounds 3, 2, 4 and 1 (each within the scatter of the next, the first and the last beyond it).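

In this assay, the first exchange measured at this place, on an aromatic carbon ortho to a large group, gives a 1.9-fold higher number from compound 3 to compound 4 (0.29 log units; within the scatter), so chloro and methyl cannot be told apart here. The comparison with the earlier 4-fluorophenyl compound gives a 1.1-fold lower number from compound 1 to compound 4 (0.05 log units; within the scatter), so 2-chlorophenyl cannot be told apart from 4-fluorophenyl either, and the small gain seen with 2-methylphenyl is not clearly shared by its chloro partner, since compound 4 lies within the scatter of both compound 1 and compound 3. Nothing available here explains these numbers.

The compounds shown leave open whether any other group at this place, such as a methoxy group, an amine or a carboxylic acid, would shift the number by clearly more than the scatter. They also leave open whether chloro and methyl would remain indistinguishable at another carbon of the same six-membered aromatic ring.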